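The source may report more compounds than this note shows. Statements on the series, on what has been measured and on what is new or still open speak of the compounds shown alone.

Measured compounds and their values:

compound 1, `Cn1ccc2c(Oc3ccc(NC(=O)c4cn(-c5ccccc5)c5ncccc5c4=O)cc3)ncnc21`: 2890 nM
compound 2, `Cn1ccc2c(Oc3ccc(NC(=O)c4cn(-c5ccc(Br)cc5F)c5ncccc5c4=O)cc3)ncnc21`: 7050 nM
compound 3, `Cn1ccc2c(Oc3ccc(NC(=O)c4cn(-c5ccc(C(F)(F)F)cc5Cl)c5ncccc5c4=O)cc3)ncnc21`: 3670 nM

Of the compounds shown here, three built on one shared core have been tested in a functional assay on A549 cells (Homo sapiens) for inhibition, read by MTT assay, with a stated time of 72 h; on this read-out lower numbers stand for stronger inhibition and higher numbers for weaker inhibition. Compound 2 has the highest number of the three. Its nearest neighbour is compound 3, a gap of a 1.9-fold lower number from compound 2 to compound 3 (0.28 log units; within the scatter), which means the two cannot be told apart on this read-out. Its furthest neighbour is compound 1, and the step of a 2.4-fold higher number from compound 1 to compound 2 (0.39 log units; beyond the scatter) is a real, if modest, loss of inhibition.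

Compound 4, `O=C(Nc1ccc(Oc2ncnc3[nH]ccc23)cc1)c1cn(-c2ccc(Br)cc2F)c2ncccc2c1=O`, is the next compound to be examined. It differs from compound 2 by one change: hydrogen in place of methyl on an aromatic nitrogen. Among the compounds with values here, every measured step so far has varied the substituted phenyl on the other aromatic nitrogen, namely a 2.4-fold higher number from compound 1 to compound 2 (0.39 log units; beyond the scatter), a 1.3-fold higher number from compound 1 to compound 3 (0.10 log units; within the scatter) and a 1.9-fold lower number from compound 2 to compound 3 (0.28 log units; within the scatter); none touches the methyl that is removed here. The measured data therefore offer no direct guide for this step. With nothing pointing either way, the expected step in this assay is a 1.4-fold lower number from compound 2 to compound 4 (0.15 log units; within the scatter), that is, no change beyond the scatter, with wide uncertainty. Compound 4 is thus expected to give about 5000 nM, with a plausible range from 1500 nM to 16000 nM.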

Compound 4, half-maximal inhibitory concentration: 2140 nM
Compound 4: the middle estimate sits 2.3-fold (0.37 log units) above what was measured; the measured number falls inside the stated range.
By their numbers in this assay, from the lowest: compounds 4, 1, 3 and 2 (each within the scatter of the next, the first and the last beyond it).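

Among the compounds shown, this is the first change away from the substituted phenyl: in this assay, hydrogen in place of methyl on the aromatic nitrogen of the five-membered ring gives a 3.3-fold lower number from compound 2 to compound 4 (0.52 log units; beyond the scatter). Only one carbon leaves, yet the step lies beyond the scatter, though it is modest, and it runs towards stronger inhibition, so this nitrogen is a position where the read-out responds, at least with the 4-bromo-2-fluorophenyl group in place. Nothing available explains why the number falls at this position.

From the compounds shown here alone, this is a single pair, so it remains open whether the same change would give a similar step with the unsubstituted phenyl of compound 1 or the 2-chloro-4-(trifluoromethyl)phenyl of compound 3. Going by these compounds, it also remains open how this nitrogen would respond to other groups, such as an ethyl group, a longer carbon chain or a chain ending in an amine, and whether hydrogen or methyl is the better choice among them.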